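The compounds below may be only part of what the source reports. "The series", "measured", "known", "first", "only" and "open" are said of these compounds alone.

Among the compounds with values here, compound 1 `C=CCN(Cc1cccs1)C(=O)COc1ccc(C)cc1` stands lowest of the three numbers so far known in an assay on HEK293 cells for agonist activity at transient receptor potential cation channel subfamily M member 8 (Homo sapiens), read by fluorescence and calcium flux, with a stated time of 15 min (on this read-out higher numbers stand for an effect only at larger amounts of compound and lower numbers for an effect already at smaller amounts), where compound 1 gives 20 nM. Within the data shown here, compound 2 `CCN(Cc1cccs1)C(=O)CCc1ccc(C)cc1` gives 93 nM in this assay, and compound 3 `CCN(Cc1cccs1)C(=O)COc1ccc(C#N)cc1` gives 1990 nM; each of them differs from compound 1 in more than one place, so no single step between measured compounds can be read off. Compound 4 `Cc1ccc(OCC(=O)N(Cc2cccs2)c2cccnc2)cc1` has not yet been measured; it differs from compound 1 by pyridin-3-yl in place of allyl on an amide-type nitrogen. Among the measured compounds shown here, no measured pair shows what such a change does, so both direction and size remain open. Compound 4 is expected to give 150 nM, with a range from 30 nM to 1500 nM. The step of a 7.5-fold higher number from compound 1 to compound 4 (0.88 log units; beyond the scatter) is estimated as a moderate rise, somewhat beyond the scatter.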

Compound 4, half-maximal effective concentration: 198 nM
Estimate against measurement, compound 4: 1.3-fold (0.12 log units) below; low and high end bracket the measured number.
By their numbers in this assay, from the lowest: compound 1; then compound 2; then compound 4; then compound 3.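

Pyridin-3-yl in place of allyl on an amide-type nitrogen gives a 9.9-fold higher number from compound 1 to compound 4 (1.00 log units; beyond the scatter) in this assay, the first change at a single place that can be read in this series. It shows that this nitrogen can carry a six-membered aromatic ring instead of allyl and still give a measurable effect, though only at a larger amount of compound. Nothing available explains this rise. The compounds shown leave open whether phenyl or pyridin-4-yl on this nitrogen would match pyridin-3-yl, and whether propyl would match allyl.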